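Replacing the 4-bromophenyl group on the amide nitrogen

The compounds below may be only part of what the source reports. "The series", "measured", "known", "first", "only" and "open" are said of these compounds alone.

Among the compounds with values here, in a functional assay on NCI-H460 cells (Homo sapiens) for inhibition, read by CCK-8 assay, with a stated time of 72 h, tested at 1 uM (on this read-out lower numbers stand for less inhibition of growth and higher numbers for more inhibition of growth at the one concentration tested), compound 3 (`CN(C)C(=O)c1cc2cnc(Nc3ccc(NC(=O)C4(C(=O)Nc5ccc(Br)cc5)CC4)cc3)nc2n1C1CCCC1`) gives 31.5%, the lowest of the three numbers so far. Compound 1 (`CN(C)C(=O)c1cc2cnc(Nc3ccc(NC(=O)C4(C(=O)Nc5cccc(F)c5)CC4)cc3)nc2n1C1CCCC1`) gives 45.1% and compound 2 (`CN(C)C(=O)c1cc2cnc(Nc3ccc(NC(=O)C4(C(=O)Nc5cccc(Cl)c5)CC4)cc3)nc2n1C1CCCC1`) gives 44%, and the two sit close together: a number 1.1 percentage points lower from compound 1 to compound 2 (within the scatter).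

The unmeasured compound 4 (`CN(C)C(=O)c1cc2cnc(Nc3ccc(NC(=O)C4(C(=O)Nc5ccc(Cl)c(C(F)(F)F)c5)CC4)cc3)nc2n1C1CCCC1`) keeps the shared core but carries 4-chloro-3-(trifluoromethyl)phenyl in place of 4-bromophenyl on an amide-type nitrogen.

Two measured steps change this same group: a number 13.6 percentage points lower from compound 1 to compound 3 (beyond the scatter) and a number 12.5 percentage points lower from compound 2 to compound 3 (beyond the scatter). Both are modest and lie beyond the scatter. The entering group resembles both sides, with a 4-chloro part recalling the 4-bromophenyl of compound 3 and a 3-substituted part recalling the 3-fluorophenyl of compound 1 and the 3-chlorophenyl of compound 2. Within the data shown here, no measured compound carries a trifluoromethyl group, so the guess is loose. A partial recovery is expected, an estimated a number 8.5 percentage points higher from compound 3 to compound 4 (within the scatter) in this assay, smaller than those two steps and possibly within the scatter.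

For compound 4 the expected value is 40%, with an estimated range from 26% to 56%.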

Compound 4, percent growth inhibition at one concentration: 2.1%
Compound 4: the middle estimate sits 37.9 percentage points above what was measured; the measured number lies below the stated range.
By their numbers in this assay, from the lowest: compound 4; then compound 3; then compounds 2 and 1 (each within the scatter of the next).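

Placing 4-chloro-3-(trifluoromethyl)phenyl on the amide-type nitrogen gives a number 29.4 percentage points lower from compound 3 to compound 4 (beyond the scatter), and the falls are larger still against the two singly halogenated rings: a number 41.9 percentage points lower from compound 2 to compound 4 (beyond the scatter) and a number 43 percentage points lower from compound 1 to compound 4 (beyond the scatter). So this position is far more sensitive than the first three compounds showed: their aryl changes left clear growth inhibition in this assay, whereas compound 4 gives only 2.1%. Nothing available explains this loss.

Whether the trifluoromethyl group alone accounts for the fall, or only does so together with the chloro group on the same ring, stays open. Also open, as far as these compounds go, is how an unsubstituted phenyl, a pyridine ring or a small alkyl chain such as ethyl would behave on this nitrogen.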